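Ring stereocentre inversion in the cyclic core of compound 3

The source may report more compounds than this note shows. Statements on the series, on what has been measured and on what is new or still open speak of the compounds shown alone.

Measured so far:
compound 1 `O=C(CC(NS(=O)(=O)c1ccc2ccccc2c1)c1ccccc1)NCc1ccc(CN2CCCCC2)cc1` gives 382 nM in an in vitro assay on CHO-D cells for displacement of a labelled ligand from B1 bradykinin receptor (Homo sapiens); on this read-out lower numbers stand for stronger inhibition and higher numbers for weaker inhibition
compound 2 `O=C(C[C@@H](NS(=O)(=O)c1ccc2ccccc2c1)c1ccccc1)NCc1ccc(CN2CCCCC2)cc1` gives 132 nM in this assay
compound 3 `CN1c2cc(CN3CCCCC3)ccc2[C@H](NC(=O)C[C@@H](NS(=O)(=O)c2ccc3ccccc3c2)c2ccccc2)CS1(=O)=O` gives 15.8 nM in this assay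

Compound 3 stands lowest of the three numbers in this assay; compound 2 is nearest and compound 1 furthest, both beyond the scatter.

Going by the values given here, compound 4 `CN1c2cc(CN3CCCCC3)ccc2[C@@H](NC(=O)C[C@@H](NS(=O)(=O)c2ccc3ccccc3c2)c2ccccc2)CS1(=O)=O` is the next one. the two compounds have the same atoms and bonds and differ only in configuration as drawn: 1 of 2 stereo elements differ; a stereocentre at a saturated ring carbon is drawn S in compound 3 and R in compound 4 Only one measured step touches configuration: a 2.9-fold lower number from compound 1 to compound 2 (0.46 log units; beyond the scatter), a modest gain that goes with the fact that one of compounds 1 and 2 is drawn with a defined configuration and the other without, at the place where they differ, the chain stereocentre being drawn without configuration in compound 1 and R in compound 2. No measured pair speaks to the ring stereocentre itself, so its weight is unknown; the one configurational step shown suggests that configuration is not indifferent in this assay.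

For compound 4 a weaker number than compound 3 is expected, with wide uncertainty, a step of a 9.5-fold higher number from compound 3 to compound 4 (0.98 log units; beyond the scatter). The estimate for compound 4 is 150 nM, between 20 nM and 1500 nM.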

Compound 4, inhibition constant: 1.3 nM
Estimate against measurement, compound 4: 120-fold (2.06 log units) above; the whole stated range lies above it.
By their numbers in this assay, from the lowest: compound 4; then compound 3; then compound 2; then compound 1.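

In this assay, the configuration of the ring stereocentre carries real weight: a 12-fold lower number from compound 3 to compound 4 (1.08 log units; beyond the scatter), with R the better of the two drawn forms at this carbon. Going by these compounds alone, the only earlier configurational step, a 2.9-fold lower number from compound 1 to compound 2 (0.46 log units; beyond the scatter), was modest and concerned the chain stereocentre, so it gave no reading at the ring carbon. The large step can be assigned to the ring stereocentre alone because nothing else separates the pair: the fact that compounds 3 and 4 differ only in the configuration as drawn

Going by these compounds, the chain stereocentre is drawn alike in compound 3 and compound 4, so how the opposite configuration there would combine with R at the ring carbon remains open. Also open, on these data alone, is whether R at the ring carbon keeps its advantage with a morpholine or a dimethylamino group in place of the present cyclic amine.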